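The compounds below may be only part of what the source reports. "The series", "measured", "known", "first", "only" and "open" are said of these compounds alone.

Measured so far:
- compound 1 `CN(C)C(=O)c1cc2cnc(Nc3ccc(NC(=O)C4(C(=O)Nc5cccc(O)c5)CC4)cc3)nc2n1C1CCCC1` with 78.5% measured
- compound 2 `Nc1ccc(NC(=O)C2(C(=O)Nc3ccc(F)cc3)CC2)cc1F` with 59.2% measured

In a functional assay on NCI-H1299 cells (Homo sapiens) for inhibition, read by CCK-8 assay, with a stated time of 72 h, tested at 10 uM (on this read-out higher numbers stand for more inhibition of growth at the one concentration tested and lower numbers for less inhibition of growth), compound 1 stands at 78.5% as the higher of the two numbers, and the gap down to compound 2 lies beyond the scatter.

Compound 3 `CN(C)C(=O)c1cc2cnc(Nc3ccc(NC(=O)C4(C(=O)Nc5cccc(Br)c5)CC4)cc3)nc2n1C1CCCC1` keeps all of compound 1 except one group: bromo in place of hydroxy on an aromatic carbon (bromo in place of hydroxy on an aromatic carbon, meta to a large group). Going by the values given here, no two measured compounds differ in one place, so no measured step speaks to this exchange, and the expectation rests on compound 1 at 78.5% alone. A small downward step within the scatter is expected in this assay rather than a clear loss. The estimated step is a number 3.5 percentage points lower from compound 1 to compound 3 (within the scatter) and stays within the scatter. Compound 3 is expected at 75% with an estimated range from 58% to 90% on this read-out.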

Compound 3, percent growth inhibition at one concentration: 77.5%
Compound 3: middle estimate off by 2.5 percentage points, on the low side; low and high end bracket the measured number.
By their numbers in this assay, from the lowest: compound 2; then compounds 3 and 1 (each within the scatter of the next).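

Bromo in place of hydroxy on an aromatic carbon gives the first measured step at this place on the shared core: in this assay the step reads a number 1 percentage points lower from compound 1 to compound 3 (within the scatter). The hydrogen-bond donor and acceptor of hydroxy leave with this exchange and bromo brings neither, yet the two numbers cannot be told apart, so this one pair gives no sign that the read-out at this single concentration depends on them. No measured evidence bears on this result.

From the compounds shown here alone, whether an amine or a carboxylic acid at this place would also stay within the scatter of compound 1 remains open. Also open, going by these compounds, is whether compound 1 and compound 3 would remain this close at other concentrations, which a single-concentration read-out cannot show.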